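A few compounds are considered here, and "the series" means these few. Any claim that something is new, unique, unknown or untested is made for them only; others in the source may bear on it.

Working notes on the series. Of the compounds shown here, three have been measured so far, all carrying the same amide-linked arrangement around the shared core and differing in the amino-acid part and in the substitution on the core. In a functional assay on the whole organism (Tail, strain ICR) with Mus musculus as the target, in the tail flick test, with a stated time of 30 min, at a dose of 25 umol/kg by the oral route (on this read-out higher numbers stand for a stronger effect at the one dose given and lower numbers for a weaker effect), compound 1 `O=C(OCc1ccccc1)[C@@H]1CCCN1C(=O)CN(c1nc(Cl)nc2[nH]cnc12)C1CC1` gives 33.2%, compound 3 `CC(C)[C@H](NC(=O)CN(c1nc(Cl)nc2[nH]cnc12)C1CC1)C(=O)O` gives 31.2%, and compound 2 `CC(C)[C@H](NC(=O)CN(c1ncnc2c1ncn2C1CCCCO1)C1CC1)C(=O)OCc1ccccc1` gives 21.8%. Compound 2 therefore holds the lowest of the three numbers; its nearest neighbour is compound 3, whose number lies higher by an amount within the usual scatter, while compound 1 is furthest away, higher by an amount beyond the scatter. For the measured compounds named here, no two of the measured compounds differ in a single place, so no isolated step between measured compounds can be read from them.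

Compound 4 `CC(C)(C)OC(=O)NCCCC[C@H](NC(=O)CN(c1ncnc2c1ncn2C1CCCCO1)C1CC1)C(=O)OCc1ccccc1` has not yet been measured in this assay . Its difference from compound 2 is 4-((tert-butoxycarbonyl)amino)butyl in place of isopropyl on a saturated chain carbon bound to an amide-type nitrogen and a carbonyl carbon. Going by the values given here, nothing among the measured compounds shows the effect of such a change at that place, and the spread of the three numbers is narrow. The step from compound 2 to compound 4 is expected to be a number 2.2 percentage points higher from compound 2 to compound 4 (within the scatter), that is, no change beyond the scatter in either direction. For compound 4 the estimate in this assay is 24%, with a range from 10% to 38%.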

Compound 4, a percentage reported as activity, at one dose (the size of the read-out at that dose, not a potency): 18.3%
Estimate against measurement, compound 4: 5.7 percentage points above, within the range that was stated.
By their numbers in this assay, from the lowest: compounds 4, 2, 3 and 1 (each within the scatter of the next, the first and the last beyond it).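

In this assay, the series now has its first step in a single place: 4-((tert-butoxycarbonyl)amino)butyl in place of isopropyl on a saturated chain carbon bound to an amide-type nitrogen and a carbonyl carbon gives a number 3.5 percentage points lower from compound 2 to compound 4 (within the scatter). At this position, then, a chain of 12 heavy atoms carrying a hydrogen-bond donor and two hydrogen-bond acceptors, in place of a group of 3 carbon atoms with neither, produces no step beyond the scatter at the one dose given. No available measurement accounts for this result.

The compounds shown leave open whether a free primary amine at the end of the butyl chain, a terminal carboxylic acid or a longer chain would also stay within the scatter of compound 2, since the tert-butoxycarbonyl group remains in place throughout this single step. They also leave open whether the same exchange would give a step of similar size on the core of compound 3, or at another dose or time in this test.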